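A few compounds are considered here, and "the series" means these few. Any claim that something is new, unique, unknown or untested is made for them only; others in the source may bear on it.

Measured so far in a functional assay on A549 cells (Homo sapiens) for cytotoxicity, read by WST assay, with a stated time of 48 h; on this read-out higher numbers stand for weaker inhibition and lower numbers for stronger inhibition:

- Compound 1 `COc1ccc2[nH]cc(/C=C(\C#N)C(=O)c3c[nH]c4ccccc34)c2c1`: 13700 nM
- Compound 2 `N#C/C(=C\c1c[nH]c2ccc(Br)cc12)C(=O)c1c[nH]c2ccc(Br)cc12`: > 50000 nM, which is a limit of the assay and not a number.
- Compound 3 `COc1ccc2[nH]cc(/C=C(\C#N)C(=O)c3c[nH]c4ccc(OC)cc34)c2c1`: 24500 nM

Among the measured compounds shown here, compound 1 holds one of only two actual numbers, and the only other number lies within the scatter of it. Compound 4 `COc1ccc2[nH]cc(/C=C(\C#N)C(=O)c3c[nH]c4cc(F)ccc34)c2c1` differs from compound 1 by fluoro in place of hydrogen on an aromatic carbon. For the measured compounds named here, one measured step bears on this change, the swap of methoxy in place of hydrogen on an aromatic carbon that leads to compound 3. Its size is a 1.8-fold higher number from compound 1 to compound 3 (0.25 log units; within the scatter). Going by the values given here, compound 2 differs from compound 1 in more than one place, so it offers no single step for comparison. Among the compounds with values here, with compound 3 as the only guide, and no fluoro compound measured yet, no step beyond the scatter is expected in this assay. The expected step is a 1.1-fold higher number from compound 1 to compound 4 (0.04 log units; within the scatter). Compound 4 is estimated at 15000 nM, with an expected range of 6000 nM to 38000 nM.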

Compound 4, half-maximal inhibitory concentration: 26300 nM
Beside the measured number, compound 4's estimate is 1.8-fold (0.24 log units) below it; the range from low to high includes it.
By their numbers in this assay, from the lowest: compounds 1, 3 and 4 (each within the scatter of the next). At a limit, above all of these: compound 2.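

In this assay, fluoro in place of hydrogen on this aromatic carbon, meta to a fused ring and para to a fused ring, gives a 1.9-fold higher number from compound 1 to compound 4 (0.28 log units; within the scatter). This position now has a direct reading for a single fluorine, and that reading does not go beyond the scatter. Alongside a 1.8-fold higher number from compound 1 to compound 3 (0.25 log units; within the scatter), it makes two single swaps on compound 1, neither of them beyond the scatter.

Going by these compounds, whether an amine or a carboxylic acid on this same carbon would give a step beyond the scatter stays open. Compound 2 stands at a limit of the assay, which is not a number, and it differs from compound 1 in more than one place, so it settles nothing about this position: the limit of > 50000 nM in this assay, at which 1 of the 4 values shown sits.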